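Working notes on tolerability across compounds 1 to 4

The compounds below may be only part of what the source reports. "The series", "measured", "known", "first", "only" and "open" are said of these compounds alone.

Measured compounds:
Compound 1, `O=C(CSc1snnc1-c1ccc(Cl)cc1Cl)Nc1ccccc1Br`, gives >= 146000 nM; this is a limit of the assay, not a number.
Compound 2, `Cc1ccc(NC(=O)CSc2snnc2-c2ccc(Cl)cc2Cl)c(Br)c1`, gives > 255000 nM; this too is a limit.
Compound 3, `O=C(CSc1snnc1-c1ccc(Cl)cc1Cl)Nc1ccccc1[N+](=O)[O-]`, gives > 283000 nM; again a limit.

All three values in an ADME assay on MT4 cells (Homo sapiens) for cytotoxicity (a higher number here means that more compound is tolerated, a lower number that less compound is tolerated), are limits, so compound 2 stands at one of three limits and cannot be ranked against the other two. The three steps between measured compounds are accordingly unreadable: a step that the two limits leave unreadable from compound 1 to compound 2, a step that the two limits leave unreadable from compound 1 to compound 3 and a step that the two limits leave unreadable from compound 2 to compound 3. The evidence itself consists only of these limits: the limit of > 255000 nM in this assay, at which 1 of the 3 values shown sits, the limit of > 283000 nM in this assay, at which 1 of the 3 values shown sits, and (the limit of >= 146000 nM in this assay, at which 1 of the 3 values shown sits).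

Compound 4, `Cc1ccc(NC(=O)CSc2snnc2-c2ccccc2)c(Br)c1`, differs from compound 2 in one place: phenyl in place of 2,4-dichlorophenyl on an aromatic carbon. Going by the values given here, none of the measured steps touches this part of the structure, so none bears directly on it. Every measured compound sits at or beyond a limit in this assay, so no step beyond the scatter is expected from compound 2 to compound 4, and the most likely outcome is again a limit. The step expected is an at least 1.0-fold lower number from compound 2 to compound 4 (0.00 log units; that floor lies within the scatter). Compound 4 is thus estimated at 250000 nM, within a range from 100000 nM to 300000 nM.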

Compound 4, half-maximal cytotoxic concentration: > 297000 nM
Compound 4: a limit, no number (the forecaster's own chance of this, stated with the estimate: 70%); at least 1.1-fold (0.07 log units) between middle value and limit.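

Compound 2 and compound 4 both stand at limits in this assay, so no step can be read between them. The compounds shown leave open what concentration any of them actually tolerates in this assay, and whether phenyl in place of 2,4-dichlorophenyl on an aromatic carbon shifts that read-out at all.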